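This account rests on a few compounds, and the source may have more. Where it says the series, first, only, none or still open, it means among the compounds named here.

Measured so far in a functional assay on HUVEC cells (Homo sapiens) for inhibition, with stated times of 2 h and 72 h; on this read-out higher numbers stand for weaker inhibition and lower numbers for stronger inhibition:
- Compound 1 `COc1cc2nccc(Oc3ccc4c(NC(=O)c5cccc(C)c5)nn(C)c4c3)c2cc1OC`: > 1000 nM, a limit
- Compound 2 `COc1ccc(Nc2nn(C)c3cc(Oc4ccnc5cc(OC)c(OC)cc45)ccc23)cc1`: > 1000 nM, a limit

Compound 2 gives only a limit, > 1000 nM, and no number. The same holds across the short series: the limit of > 1000 nM in this assay, at which 2 of the 2 values shown sit.

Compound 3 `COc1cc2nccc(Oc3ccc4c(Nc5ccccc5)nn(C)c4c3)c2cc1OC` has hydrogen in place of methoxy on an aromatic carbon, para to a large group, so that 4-methoxyphenyl becomes phenyl: hydrogen in place of methoxy on an aromatic carbon.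

For the measured compounds named here, the only measured step that bears on this change is a step that the two limits leave unreadable from compound 1 to compound 2. Going by the values given here, it offers no size to carry over, and no measured step shows the effect of removing this methoxy. No step beyond the usual scatter is therefore expected in this assay, and no direction can be argued. The estimated step is a step that the limit leaves unreadable from compound 2 to compound 3. Compound 3 is expected at 2000 nM, with an estimated range of 400 nM to 10000 nM.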

Compound 3, half-maximal inhibitory concentration: > 1000 nM
Compound 3 was reported as a limit; the forecaster's own chance of this, stated with the estimate: 70%; the middle value lies beyond the limit too.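

In this assay compound 3 gives > 1000 nM, a limit and not a number. No step can be read among compound 1, compound 2 and compound 3, and the series stays at one value: the limit of > 1000 nM in this assay, at which 3 of the 3 values shown sit. The compounds shown leave open how strongly each inhibits and whether removing the methoxy changes this at all.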